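A few compounds are considered here, and "the series" means these few. Any claim that something is new, unique, unknown or untested is made for them only; others in the source may bear on it.

In a functional assay on HEp-2 cells (Homo sapiens) for cytotoxicity, read by sulforhodamine B assay, with a stated time of 48 h (a lower number here means a stronger inhibitor, a higher number a weaker inhibitor), compound 2 `O=CCN1N=C(c2ccc3ccccc3c2)CC1c1ccco1` gives 19000 nM, the higher of the two numbers measured, while compound 1 `O=CCN1N=C(c2ccc3ccccc3c2)CC1c1cccc(Br)c1` gives 8780 nM. Among the compounds with values here, the single measured step, a 2.2-fold higher number from compound 1 to compound 2 (0.34 log units; beyond the scatter), is the only comparison that bears on compound 3 `COc1ccc(C2CC(c3ccc4ccccc4c3)=NN2CC=O)cc1`. Compound 3 differs from compound 2 in that (4-methoxyphenyl in place of furan-2-yl on a saturated ring carbon). The entering 4-methoxyphenyl shares with the 3-bromophenyl of compound 1 a six-membered aromatic ring of carbon only. On that basis the step of a 1.7-fold lower number from compound 2 to compound 3 (0.24 log units; within the scatter) is expected to be modest and toward a lower number. Compound 3 is therefore estimated at 11000 nM, within 5000 nM to 25000 nM.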

Compound 3, half-maximal inhibitory concentration: 3230 nM
Estimate against measurement, compound 3: 3.4-fold (0.53 log units) above; the measured number lies below the stated range.
By their numbers in this assay, from the lowest: compound 3; then compound 1; then compound 2.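

In this assay the change on this saturated ring carbon goes further than the earlier pair showed, with a 5.9-fold lower number from compound 2 to compound 3 (0.77 log units; beyond the scatter) and a 2.7-fold lower number from compound 1 to compound 3 (0.43 log units; beyond the scatter). The two groups with a six-membered aromatic ring of carbon only therefore do not read alike, so the ring type alone does not set the number here, and 4-methoxyphenyl gives the lowest of the three. No measurement at hand accounts for this result. On these data alone, it remains open whether 3-methoxyphenyl or 4-bromophenyl would separate the group from where it sits on the ring, and how a ring bearing an amine, as in 4-aminophenyl, would compare.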